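Swapping the Terminal Aryl Group in Three Cell Inhibitors

A few compounds are considered here, and "the series" means these few. Any claim that something is new, unique, unknown or untested is made for them only; others in the source may bear on it.

Compound 1 `COc1ccccc1-c1ccc(CNc2nc(NC3CCC(N)CC3)nc3c2ncn3C2CCCC2)cc1`: 150 nM
Compound 2 `NC1CCC(Nc2nc(NCc3ccc(-c4cccc(F)c4)cc3)c3ncn(C4CCCC4)c3n2)CC1`: 211 nM
Compound 3 `NC1CCC(Nc2nc(NCc3ccc(-n4cccn4)cc3)c3ncn(C4CCCC4)c3n2)CC1`: 103 nM

In a functional assay on HOS cells (Homo sapiens) for inhibition, with a stated time of 72 h (on this read-out higher numbers stand for weaker inhibition and lower numbers for stronger inhibition), compound 3 gives the lowest of the three numbers, though only the gap to compound 2 lies beyond the scatter, so compound 3 is not clearly the strongest. Compound 4 `NC1CCC(Nc2nc(NCc3ccc(-c4ccsc4)nc3)c3ncn(C4CCCC4)c3n2)CC1` differs from compound 3 in one place: 6-(thiophen-3-yl)pyridin-3-yl in place of 4-(1H-pyrazol-1-yl)phenyl on a saturated chain carbon bound to a nitrogen on an aromatic ring. Within the data shown here, the steps that bear on this are the earlier exchanges of the terminal aryl group, a 1.4-fold higher number from compound 1 to compound 2 (0.15 log units; within the scatter), a 1.5-fold lower number from compound 1 to compound 3 (0.16 log units; within the scatter) and a 2.0-fold lower number from compound 2 to compound 3 (0.31 log units; beyond the scatter), all small. The analogous exchange here is therefore expected to give no step beyond the scatter, a 1.5-fold higher number from compound 3 to compound 4 (0.16 log units; within the scatter). Compound 4 is estimated at 150 nM, with a range from 60 nM to 400 nM.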

Compound 4, half-maximal inhibitory concentration: 89 nM
For compound 4 the middle estimate is 1.7-fold (0.23 log units) above the measured one; the measured number falls inside the stated range.
By their numbers in this assay, from the lowest: compounds 4, 3, 1 and 2 (each within the scatter of the next, the first and the last beyond it).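

The exchange gives a 1.2-fold lower number from compound 3 to compound 4 (0.06 log units; within the scatter) in this assay, so this position accepts 6-(thiophen-3-yl)pyridin-3-yl in place of 4-(1H-pyrazol-1-yl)phenyl with no step beyond the scatter. Compounds 1, 2 and 3 keep the same six-membered aromatic ring of carbon only, whereas compound 4 shows that a six-membered aromatic ring with a hetero atom can stand there as well. Nothing available explains this outcome. The compounds shown leave open what either ring exchange does alone, and how a carboxylic acid in place of the terminal ring would read in this assay.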